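The source may hold more compounds than are shown below. What is called first, only, known or untested is meant among the compounds shown, and "the series" means these compounds.

Measured in an ADME assay on HepG2 2.2.15 cells (Homo sapiens) for cytotoxicity; on this read-out higher numbers stand for lower toxicity in this test and lower numbers for higher toxicity in this test:
Compound 1 `CC(C)C(=O)OCCc1c(-c2ccccc2Cl)c2cc(Cl)ccc2[nH]c1=O`: 62000 nM
Compound 2 `CCOCC(=O)OCCc1c(-c2ccccc2Cl)c2cc(Cl)ccc2[nH]c1=O`: 130000 nM

Of these two, compound 2 holds the higher number, 130000 nM, so it stands at the less toxic end of the pair. The next compound, compound 3 `CC12CCC(C(=O)OCCc3c(-c4ccccc4Cl)c4cc(Cl)ccc4[nH]c3=O)(OC1=O)C2(C)C`, keeps the shared core and changes only the group on the carbonyl carbon: a group of 11 heavy atoms (9 carbon, 2 oxygen; one five-membered non-aromatic ring of carbon only, one five-membered non-aromatic ring with 1 hetero atom) in place of a group of 4 heavy atoms (3 carbon, 1 oxygen; no ring), on a carbonyl carbon. For the measured compounds named here, one measured step bears on this place, a 2.1-fold higher number from compound 1 to compound 2 (0.32 log units; beyond the scatter). It was modest and only just beyond the scatter. Going by the values given here, no measured compound carries a group with a ring at this carbonyl carbon, so that step is a rough guide and no more. In this assay the expectation is therefore a step no larger than that one, perhaps within the scatter, and tilted toward a lower number, given that compound 2 at 130000 nM is the higher of the two values. The expected step is a 1.6-fold lower number from compound 2 to compound 3 (0.21 log units; within the scatter). For compound 3 the estimated value is 80000 nM, with an expected range from 30000 nM to 200000 nM.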

Compound 3, half-maximal cytotoxic concentration: > 1800000 nM
Compound 3 was reported as a limit; the forecaster's own chance of this, stated with the estimate: 15%; at least 22-fold (1.35 log units) between middle value and limit.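

In this assay, the place on the carbonyl carbon turns out to matter far more than the two open-chain groups suggested: setting the group of 11 heavy atoms, with its two five-membered rings, in place of ethoxymethyl gives an at least 13-fold higher number from compound 2 to compound 3 (1.14 log units; beyond the scatter), and setting it in place of isopropyl gives an at least 29-fold higher number from compound 1 to compound 3 (1.46 log units; beyond the scatter). For the compounds shown here, both steps are large, whereas the only earlier step at this place, a 2.1-fold higher number from compound 1 to compound 2 (0.32 log units; beyond the scatter), was modest, so a ring-bearing group here moves the compound much further toward the less toxic end of this test than a swap between small open chains does. For compound 3 the reading is a limit and not a number: the limit of > 1800000 nM in this assay, at which 1 of the 3 values shown sits.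

The compounds shown leave open which feature of the entering group goes with this large step, since a cyclopentyl group, with a single ring of carbon only, or a longer open carbon chain on the same carbonyl carbon would separate the presence of rings from plain size. They also leave the full size of both steps unsettled, as each is known only as a minimum.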